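The source may hold more compounds than are shown below. What is called first, only, known or untested is meant among the compounds shown, and "the series" means these compounds.

Working notes on the series built on the shared core of compound 1 `O=c1c2cnn(-c3ccc(F)cc3)c2ncn1CC1(O)CCN(Cc2ccncc2)CC1`, for which an assay on Sf21 cells for inhibition of ubiquitin carboxyl-terminal hydrolase 7 (Homo sapiens), read by spectrophotometry, with stated times of 30 min and 2 h (on this read-out higher numbers stand for weaker inhibition and lower numbers for stronger inhibition), reports "not determined" (no result reported). Compound 2 `O=c1c2cnn(-c3ccc(F)cc3)c2ncn1CC1(O)CCN(Cc2ccccc2F)CC1` gives 9800 nM in this assay. Compound 3 `O=c1c2cnn(-c3ccc(F)cc3)c2ncn1CC1(O)CCN(Cc2ccccc2Cl)CC1` gives 3400 nM and so stands lowest of the two numbers in hand; the step of a 2.9-fold lower number from compound 2 to compound 3 (0.46 log units; beyond the scatter) came with chloro in place of fluoro on an aromatic carbon, modest but beyond the scatter. Compound 4 `O=c1c2cnn(-c3ccc(F)cc3)c2ncn1CC1(O)CCN(Cc2ccccc2Br)CC1` differs from compound 3 by bromo in place of chloro on an aromatic carbon. Going by the values given here, only the step from compound 2 to compound 3 bears on this change, and it ran toward lower numbers; a further step in the same direction but smaller, possibly within the scatter, is expected. Compound 4 is therefore estimated at 2000 nM (range 800 nM to 6000 nM), an expected step of a 1.7-fold lower number from compound 3 to compound 4 (0.23 log units; within the scatter).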

Compound 4, half-maximal inhibitory concentration: 3100 nM
Compound 4: the middle estimate sits 1.6-fold (0.19 log units) below what was measured, within the range that was stated.
By their numbers in this assay, from the lowest: compounds 4 and 3 (each within the scatter of the next); then compound 2.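

In this assay the change from 2-chlorobenzyl to 2-bromobenzyl gives a 1.1-fold lower number from compound 3 to compound 4 (0.04 log units; within the scatter) and so does not separate these two halogens at this place. With a 3.2-fold lower number from compound 2 to compound 4 (0.50 log units; beyond the scatter) alongside a 2.9-fold lower number from compound 2 to compound 3 (0.46 log units; beyond the scatter) the change away from fluoro is the one that registers, and the run toward lower numbers does not carry on past chloro. No measured evidence accounts for this pattern. Open, as far as these compounds go, is whether anything other than a halogen at this place, such as methoxy, nitrile or an amine, would move the number beyond the scatter.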